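The compounds below may be only part of what the source reports. "The series", "measured", "known", "first", "only" and "open" are said of these compounds alone.

Working notes on the diaryl ether thiourea series.

Of the compounds shown here, two have numbers so far. Compound 1 `CNC(=O)c1ccc(Oc2cccc(NC(=S)Nc3ccc(OC(F)(F)F)cc3)c2)nc1` and compound 2 `CNC(=O)c1ccc(Oc2cccc(NC(=S)Nc3ccc(Cl)cc3Cl)c2)nc1` share the same core and differ only in the aryl group on the thiourea. Compound 1 reports only a limit in a functional assay on PC-3 cells (Homo sapiens) for antiproliferative activity, read by MTT assay (a lower number here means a stronger inhibitor, a higher number a weaker inhibitor), > 100000 nM, and no number. In this assay compound 2 gives 19300 nM. Compound 2 thus holds the only number shown; the other value, for compound 1, sits at the limit (the limit of > 100000 nM in this assay, at which 1 of the 2 values shown sits). Within the data shown here, with no pair differing in one place among the measured compounds, no step size is available from the data.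

Compound 3 `CNC(=O)c1ccc(Oc2cccc(NC(=S)Nc3ccc(Cl)cc3)c2)nc1` is not yet measured. It differs from compound 2 by hydrogen in place of chloro on an aromatic carbon, the change sitting on an aromatic carbon of a six-membered aromatic ring of carbon only, ortho to a large group and meta to the remaining chloro group; read one bond further out, 2,4-dichlorophenyl becomes 4-chlorophenyl.

Among the measured compounds shown here, no measured step supports a direction here. The step from compound 2 to compound 3 is expected to be small and toward a weaker inhibitor, a 1.6-fold higher number from compound 2 to compound 3 (0.19 log units; within the scatter), not clearly beyond the scatter. In this assay compound 3 is estimated at 30000 nM, with a range from 10000 nM to 100000 nM.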

Compound 3, half-maximal inhibitory concentration: 28400 nM
Compound 3: middle estimate off by 1.1-fold (0.02 log units), on the high side; low and high end bracket the measured number.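

In this assay the step from 2,4-dichlorophenyl to 4-chlorophenyl reads as a 1.5-fold higher number from compound 2 to compound 3 (0.17 log units; within the scatter), so at this place, ortho to a large group and meta to the remaining chloro group, chloro and hydrogen are not told apart by this read-out. The series also gains its first step beyond the scatter, for chloro in place of trifluoromethoxy on an aromatic carbon: an at least 3.5-fold lower number from compound 1 to compound 3 (0.54 log units; beyond the scatter), which makes the group on this other aromatic carbon, not the one just emptied, the only place shown where a change registers. That step gives a lower bound and not a size, as compound 1 stands at a limit and has no number: the limit of > 100000 nM in this assay, at which 1 of the 3 values shown sits.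

As far as these compounds go, what an amine, a carboxylic acid or a methoxy group would do in place of the remaining chloro group stays open, as does the outcome with hydrogen there. The compounds shown vary only the aryl group on the thiourea, and a urea in place of the thiourea, or any other change to the shared core, remains an open question.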